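Thiophene Replaces Methoxyphenyl on the Weakest Compound

The source may hold more compounds than are shown below. What is called first, only, known or untested is meant among the compounds shown, and "the series" means these compounds.

Measured so far in a functional assay on cells for antagonist activity at prostaglandin E2 receptor EP1 subtype (Rattus norvegicus), read by fluorescence and calcium flux, with a stated time of 60 s (a lower number here means a stronger inhibitor, a higher number a weaker inhibitor), are three compounds:
Compound 1 `O=C(O)c1cccc(Cc2c(-c3ccccc3)nn3cc(F)ccc23)n1` gives 380 nM.
Compound 2 `CSc1ccc2c(Cc3cccc(C(=O)O)n3)c(-c3ccccc3)nn2c1` gives 87 nM.
Compound 3 `COc1ccc(-c2nn3cc(Cl)ccc3c2Cc2cccc(C(=O)O)n2)cc1` gives 5400 nM.

Compound 3 stands highest of the three numbers, beyond the scatter from compound 1 and further still from compound 2. Among the compounds with values here, the only single-point step among the measured compounds is a 4.4-fold lower number from compound 1 to compound 2 (0.64 log units; beyond the scatter), which concerns a different place on the shared core and does not bear on the change in hand.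

Compound 4 `O=C(O)c1cccc(Cc2c(-c3ccsc3)nn3cc(Cl)ccc23)n1` differs from compound 3 by thiophen-3-yl in place of 4-methoxyphenyl on an aromatic carbon. Within the data shown here, no measured step covers this change. Compound 1 carries a plain phenyl at the same place and gives 380 nM, while compound 3 with its 4-methoxyphenyl gives 5400 nM; the two differ in two places, so no single step can be read from them. Thiophen-3-yl is a smaller ring than 4-methoxyphenyl, and a lower number than that of compound 3 is expected, though with wide uncertainty. For compound 4 the estimate is 600 nM, in the range 150 nM to 3000 nM, an expected step of a 9.0-fold lower number from compound 3 to compound 4 (0.95 log units; beyond the scatter).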

Compound 4, half-maximal inhibitory concentration: 110 nM
For compound 4 the middle estimate is 5.5-fold (0.74 log units) above the measured one, outside the stated range (below it).
By their numbers in this assay, from the lowest: compounds 2 and 4 (each within the scatter of the next); then compound 1; then compound 3.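

Within the data shown here, this is the first step at this position that can be read on its own, on an aromatic carbon of the five-membered aromatic ring with 2 nitrogen, and it is large. In this assay the swap gives a 49-fold lower number from compound 3 to compound 4 (1.69 log units; beyond the scatter) with the rest of the structure unchanged, so the number is highly sensitive to the group held at this place, whereas the earlier step concerned a different place on the shared core. Nothing measured here accounts for the size of this step.

The compounds shown leave open whether the shift belongs to the thiophene ring itself or to the loss of the 4-methoxyphenyl group. A plain phenyl on the chlorinated core, and rings such as thiophen-2-yl or furan-3-yl at this place, would help separate those two readings.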